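The source may report more compounds than this note shows. Statements on the series, on what has been measured and on what is new or still open speak of the compounds shown alone.

Measured compounds in a functional assay on SW-620 cells (Homo sapiens) for antiproliferative activity, read by MTT assay, with a stated time of 72 h; on this read-out higher numbers stand for weaker inhibition and lower numbers for stronger inhibition:
compound 1, `Cc1ccc(S(=O)(=O)NCc2cn(C[C@H](O)[C@H]3OC(=O)C(OCc4ccccc4)=C3OCc3ccccc3)nn2)cc1`, with 45800 nM
compound 2, `O=C1O[C@H]([C@@H](O)Cn2cc(CNS(=O)(=O)c3ccc(Cl)cc3F)nn2)C(OCc2ccccc2)=C1OCc1ccccc1`, with 42400 nM
compound 3, `Cc1ccc(-c2cn(C[C@H](O)[C@H]3OC(=O)C(OCc4ccccc4)=C3OCc3ccccc3)nn2)cc1`, with > 100000 nM

Compound 1 and compound 2 both return weak numbers in this assay. Compound 3 gives only a limit of the assay, > 100000 nM, and no number. This is the upper edge at which one of the three values sits (the limit of > 100000 nM in this assay, at which 1 of the 3 values shown sits). Of the two measured steps, a 1.1-fold lower number from compound 1 to compound 2 (0.03 log units; within the scatter), while an at least 2.1-fold higher number from compound 1 to compound 3 (0.33 log units; beyond the scatter). Compound 4, `O=C1O[C@H]([C@@H](O)Cn2ccnn2)C(OCc2ccccc2)=C1OCc1ccccc1`, is not yet measured. It differs from compound 3 in one place: hydrogen in place of 4-methylphenyl on an aromatic carbon. Among the measured compounds shown here, no measured step removes the 4-methylphenyl from this aromatic carbon, so the only direct guide is that compound 3 already sits at the limit. Compound 4 is expected to remain at or beyond that limit, with an estimate of 150000 nM, in a range from 50000 nM to 500000 nM. For compound 4 this estimate means a step that the limit leaves unreadable from compound 3 to compound 4, most likely reported again as a limit rather than a number.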

Compound 4, half-maximal inhibitory concentration: > 100000 nM
Compound 4: a limit, no number; the forecaster's own chance of this, stated with the estimate: 70%; the middle value is on the limit's open side.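

In this assay compound 4 gives > 100000 nM, which is a limit and not a number. The step between compound 3 and compound 4 cannot be read, so these data show no change in either direction when hydrogen replaces 4-methylphenyl on this aromatic carbon: the limit of > 100000 nM in this assay, at which 2 of the 4 values shown sit. Removing the whole (((4-methylphenyl)sulfonyl)amino)methyl group gives an at least 2.1-fold higher number from compound 1 to compound 4 (0.33 log units; beyond the scatter), so among these four compounds a readable number appears only with a sulfonyl-bearing chain at this place.

From the compounds shown here alone, it remains open whether another group on this aromatic carbon, such as an aminomethyl or a carboxylic acid, would return a readable number. Going by these compounds, it also remains open how far beyond the limit compound 3 and compound 4 actually lie.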